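Aryl swap on the sulfonamide nitrogen: compound 3 to compound 4

The source may hold more compounds than are shown below. What is called first, only, known or untested is meant among the compounds shown, and "the series" means these compounds.

Values in a functional assay on DU-145 cells (Homo sapiens) for antiproliferative activity, read by MTT assay, with a stated time of 72 h; on this read-out higher numbers stand for weaker inhibition and lower numbers for stronger inhibition:
- Compound 1 `CN(c1ccccc1)S(=O)(=O)C1CC2OC1C(c1ccc(NC(=O)CCCCCCC(=O)O)cc1)=C2c1ccc(O)cc1`: > 100000 nM (a limit)
- Compound 2 `CN(c1ccc(Cl)cc1)S(=O)(=O)C1CC2OC1C(c1ccc(NC(=O)CCCCCCC(=O)O)cc1)=C2c1ccc(O)cc1`: 72100 nM
- Compound 3 `CCN(c1cccc(OC)c1)S(=O)(=O)C1CC2OC1C(c1ccc(NC(=O)CCCCCCC(=O)O)cc1)=C2c1ccc(O)cc1`: 71100 nM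

Going by the values given here, only two of these three readings are numbers. Compound 1 stands at the limit of > 100000 nM in this assay, at which 1 of the 3 values shown sits, and that is a limit of the assay. Among the compounds with values here, compound 3 gives 71100 nM, and the only other number lies very close: a 1.0-fold lower number from compound 2 to compound 3 (0.01 log units; within the scatter). That pair cannot be ranked.

Compound 4 `CCN(c1ccc(O)cc1)S(=O)(=O)C1CC2OC1C(c1ccc(NC(=O)CCCCCCC(=O)O)cc1)=C2c1ccc(O)cc1` keeps the shared core and the ethyl group on the sulfonamide nitrogen, with 4-hydroxyphenyl in place of 3-methoxyphenyl on a sulfonamide nitrogen.

The measured steps that bear on this change all alter the substituents on that same nitrogen or its aryl ring. The exchange of one whole aryl amino group for another gave a 1.0-fold lower number from compound 2 to compound 3 (0.01 log units; within the scatter). The two steps that start from the limit, an at least 1.3-fold lower number from compound 1 to compound 2 (0.14 log units; that floor lies within the scatter) and an at least 1.4-fold lower number from compound 1 to compound 3 (0.14 log units; that floor lies within the scatter), give only floors, and these stay within the scatter. On this evidence, no step beyond the scatter is expected in this assay. The expected step is a 1.1-fold lower number from compound 3 to compound 4 (0.04 log units; within the scatter). The estimate for compound 4 is 65000 nM, with an expected range from 30000 nM to 100000 nM.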

Compound 4, half-maximal inhibitory concentration: > 100000 nM
Compound 4 was reported as a limit (the forecaster's own chance of this, stated with the estimate: 25%); middle value at least 1.5-fold (0.18 log units) from the limit.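

In this assay compound 4 gives > 100000 nM, which is a limit of the assay and not a number. Placing 4-hydroxyphenyl in place of 3-methoxyphenyl on the sulfonamide nitrogen gives an at least 1.4-fold higher number from compound 3 to compound 4 (0.14 log units; that floor lies within the scatter), and the wider exchange of the whole amino group gives an at least 1.3-fold higher number from compound 2 to compound 4 (0.14 log units; that floor lies within the scatter); both are only floors within the scatter, so they show that keeping the ethyl group on that nitrogen does not by itself hold a compound off the limit, but they establish no real loss. The step from compound 1 to compound 4 cannot be read, and the limit now bounds much of what is shown on this nitrogen: the limit of > 100000 nM in this assay, at which 2 of the 4 values shown sit.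

The change from 3-methoxyphenyl to 4-hydroxyphenyl alters the oxygen substituent and its ring place together, so the compounds shown cannot separate the two, as 3-hydroxyphenyl or 4-methoxyphenyl on the same nitrogen might. They also leave open whether any group there, such as an aminophenyl or a longer chain in place of the ethyl group, would give a reading clearly apart from these.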